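The compounds below may be only part of what the source reports. "The series", "measured", "known", "first", "only" and "open" are said of these compounds alone.

In a functional assay on HL-60 cells (Homo sapiens) for antiproliferative activity, read by MTT assay, with a stated time of 48 h (a lower number here means a stronger inhibitor, a higher number a weaker inhibitor), two macrocyclic compounds have been measured so far. Compound 1 `COC/C1=C/C[C@](C)(CCC=C(C)C)/C=C/[C@@H](OC(=O)C=C(C)C)[C@](C)(O)/C=C/C1=O` gives 3070 nM in this assay. Compound 2 `C=C1/C=C/C(=O)/C(CO)=C\C[C@](C)(CCC=C(C)C)/C=C/[C@H]1OC(=O)C=C(C)C` gives 2810 nM in this assay, and the two numbers lie within the usual scatter of each other, so neither compound can be called stronger than the other. Compound 3 `CC(C)=CCC[C@]1(C)/C=C/[C@@H](OC(=O)C=C(C)C)[C@](C)(O)/C=C/C(=O)/C(C(=O)N(C(C)C)C(C)C)=C\C1` has not yet been measured; it differs from compound 1 in one place (diisopropylcarbamoyl in place of methoxymethyl on a double-bonded ring carbon). Among the measured compounds shown here, no step between measured compounds that differ in a single position is available, so the effect of this exchange can only be guessed from the level at which compound 1 sits. With the number for compound 1 as the anchor, the step from compound 1 to compound 3 is expected to be no larger than the scatter, in either direction, as a 1.1-fold higher number from compound 1 to compound 3 (0.06 log units; within the scatter). Compound 3 is therefore estimated at 3500 nM, with a range from 1200 nM to 10000 nM.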

Compound 3, half-maximal inhibitory concentration: 12700 nM
Compound 3: middle estimate off by 3.6-fold (0.56 log units), on the low side; the whole stated range lies below it.
By their numbers in this assay, from the lowest: compounds 2 and 1 (each within the scatter of the next); then compound 3.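

In this assay, diisopropylcarbamoyl in place of methoxymethyl on the double-bonded ring carbon gives a 4.1-fold higher number from compound 1 to compound 3 (0.62 log units; beyond the scatter), so this position does not accept every group without a change beyond the scatter. The earlier compounds shown here offered no single-place step, and this one shows that the number responds to the group at this carbon. The entering group has more heavy atoms than the one it replaces, with the same counts of hydrogen-bond donors and acceptors, but no measurement at hand accounts for the step.

A single pair leaves open whether the number follows the size of the group or its amide character, which a dimethylcarbamoyl group or a carboxylic acid at this carbon would help to separate. Going by these compounds, whether the same exchange would act alike on the core of compound 2 also remains open.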